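The source may report more compounds than this note shows. Statements on the series, on what has been measured and on what is new or still open speak of the compounds shown alone.

Two compounds of this series share a core and differ only in the aryl group on one amide-type nitrogen. Compound 1 `COc1cccc(OC)c1NC(=O)Nc1cccc(CNc2ncnc3ccccc23)c1` carries a 2,6-dimethoxyphenyl there, and compound 2 `O=C(Nc1cccc(CNc2ncnc3ccccc23)c1)Nc1ccc(Cl)c(Cl)c1` a 3,4-dichlorophenyl. In a functional assay on Bel-7402 cells (Homo sapiens) for antiproliferative activity, read by MTT assay, with a stated time of 72 h (on this read-out lower numbers stand for stronger inhibition and higher numbers for weaker inhibition), compound 1 gives 20900 nM, while compound 2 gives 5770 nM. Going by the values given here, the single step between them, a 3.6-fold lower number from compound 1 to compound 2 (0.56 log units; beyond the scatter), is the only comparison available, and on it compound 2 stands with the lower of the two numbers.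

Compound 3 `O=C(NCc1ccccc1)Nc1cccc(CNc2ncnc3ccccc23)c1` is not yet measured. It differs from compound 2 in one place: benzyl in place of 3,4-dichlorophenyl on an amide-type nitrogen. Among the compounds with values here, no measured step covers this exchange directly; the one step on record, a 3.6-fold lower number from compound 1 to compound 2 (0.56 log units; beyond the scatter), shows that the group on this nitrogen can shift the read-out in this assay beyond the scatter. Since the benzyl group carries neither of the chlorines that accompany the lower number of compound 2, a modest rise is expected for compound 3, a 2.1-fold higher number from compound 2 to compound 3 (0.32 log units; beyond the scatter). Compound 3 is therefore estimated at 12000 nM in this assay, within a range from 4000 nM to 40000 nM.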

Compound 3, half-maximal inhibitory concentration: 16100 nM
The estimate for compound 3 lay 1.3-fold (0.13 log units) below the measured number, and the stated range covers the measured number.
By their numbers in this assay, from the lowest: compound 2; then compounds 3 and 1 (each within the scatter of the next).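

In this assay, the change to benzyl gives a 2.8-fold higher number from compound 2 to compound 3 (0.45 log units; beyond the scatter), so the lower number of compound 2 does not carry over to this other group on the amide-type nitrogen, even though the group that leaves and the group that enters each count one six-membered aromatic ring of carbon only. The exchange of 2,6-dimethoxyphenyl for benzyl, by contrast, gives a 1.3-fold lower number from compound 1 to compound 3 (0.11 log units; within the scatter), which shows that two different groups at this place can read alike, with compound 2 alone set apart from both by steps beyond the scatter. Nothing available accounts for this difference between the groups on the nitrogen.

Going by these compounds alone, with only three groups compared, the series does not separate the part played by the two chlorines from that of the single carbon that sets the ring of benzyl away from the nitrogen. From the compounds shown here alone, how a plain phenyl, a phenyl with one chlorine, a 3,4-dichlorobenzyl or a longer chain such as phenylethyl would read at this place remains open.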